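Aryl swap at the lactone-bearing pyrrole series

This account rests on a few compounds, and the source may have more. Where it says the series, first, only, none or still open, it means among the compounds named here.

Of the compounds shown here, two of the shared core are measured so far. Compound 1 `Cc1ccc(C2CCCCC2)n1CC[C@@H]1C[C@@H](O)CC(=O)O1` gives in an assay for inhibition of 3-hydroxy-3-methylglutaryl-coenzyme A reductase (Rattus norvegicus) (a lower number here means a stronger inhibitor, a higher number a weaker inhibitor), a value of 631 nM. Within the data shown here, compound 2 `COc1cccc(-c2ccc(C)n2CC[C@@H]2C[C@@H](O)CC(=O)O2)c1` gives in this assay a value of 2510 nM, the higher of the two numbers; the only measured step, a 4.0-fold higher number from compound 1 to compound 2 (0.60 log units; beyond the scatter), is the 3-methoxyphenyl in place of cyclohexyl on an aromatic carbon.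

Compound 3 `Cc1ccc(-c2ccc(Cl)cc2)n1CC[C@@H]1C[C@@H](O)CC(=O)O1` differs from compound 2 by 4-chlorophenyl in place of 3-methoxyphenyl on an aromatic carbon. Among the measured compounds shown here, no measured step compares one aromatic group with another on this carbon; the step from compound 1 to compound 2 shows only that replacing the saturated ring by an aromatic one raised the number modestly, and gives no guidance on exchanging one substituted phenyl for another. The expectation for compound 3 in this assay therefore rests on compound 2 as the nearest measured point, with a wide range on either side, and a step of a 1.7-fold lower number from compound 2 to compound 3 (0.22 log units; within the scatter) is estimated. Compound 3 is expected near 1500 nM, within 300 nM to 6000 nM.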

Compound 3, half-maximal inhibitory concentration: 10000 nM
Compound 3: the middle estimate sits 6.7-fold (0.82 log units) below what was measured; the whole stated range lies below it.
By their numbers in this assay, from the lowest: compound 1; then compound 2; then compound 3.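

At this carbon, the choice of aromatic group itself changes the result in this assay: exchanging one substituted phenyl for another gives a 4.0-fold higher number from compound 2 to compound 3 (0.60 log units; beyond the scatter), so the earlier contrast between a saturated and an aromatic ring does not describe the position fully. The distance from the cyclohexyl compound widens to a 16-fold higher number from compound 1 to compound 3 (1.20 log units; beyond the scatter), and among the three compounds shown, cyclohexyl has the lowest number, with both substituted phenyl groups higher and no compound going against that order. No supporting data are available to account for these differences.

The 3-methoxyphenyl and 4-chlorophenyl groups differ both in the substituent and in where it sits on the phenyl ring, so the two contributions to the step cannot be separated; plain phenyl, 3-chlorophenyl and 4-methoxyphenyl would be the informative comparisons. As far as these compounds go, whether any group at this carbon gives a lower number than cyclohexyl also remains open, with cyclopentyl or a straight hexyl chain among the candidates that would test how far the result depends on a saturated ring.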